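Lengthening the ether-linked hydroxamate chain of a dual hydroxamic acid

This account rests on a few compounds, and the source may have more. Where it says the series, first, only, none or still open, it means among the compounds named here.

Measured compounds:
Compound 1, `CC(C)CCc1c(OCCCCCC(=O)NO)ccc(CCC(=O)NO)c1O`: in a functional assay on Hep 3B2 cells (Homo sapiens) for antiproliferative activity, read by sulforhodamine B assay, with a stated time of 48 h (on this read-out higher numbers stand for weaker inhibition of growth and lower numbers for stronger inhibition of growth), compound 1 gives 1980 nM.
Compound 2, `CC(C)CCc1c(OCCCCCCCC(=O)NO)ccc2c1OC(=O)CC2`: compound 2 reaches only > 30000 nM, which is a limit of the assay rather than a number, (the limit of > 30000 nM in this assay, at which 1 of the 3 values shown sits).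
Compound 3, `CC(C)CCc1c(OCCCCCCCC(=O)NO)ccc2ccc(=O)oc12`: compound 3 gives 3580 nM.

Compound 1 carries the lowest of the two numbers available, but its nearest neighbour, compound 3, sits within the usual scatter of it, so no order between the two can be drawn. Compound 2, which shares the longer ether chain with compound 3 but has a different core, gave only a limit.

Compound 4, `CC(C)CCc1c(OCCCCCCCC(=O)NO)ccc(CCC(=O)NO)c1O`, keeps the core of compound 1 and differs from it in a single place: 2-(hydroxycarbamoyl)ethyl in place of hydroxycarbamoyl on a saturated chain carbon, five bonds along the chain from an oxygen on an aromatic ring. The hydroxamic acid at the end of the ether chain is thereby pushed further out from the aromatic oxygen, while the second hydroxamic acid on the core is unchanged.

Among the compounds with values here, no measured pair in this set isolates such a chain extension, so the direction of the step is expected to be small, with the step from compound 1 to compound 4 estimated at a 1.3-fold lower number from compound 1 to compound 4 (0.12 log units; within the scatter), essentially none beyond the scatter. Compound 4 is therefore expected to give about 1500 nM, with a range from 600 nM to 4000 nM.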

Compound 4, concentration for 50% growth inhibition: 1270 nM
Estimate against measurement, compound 4: 1.2-fold (0.07 log units) above; low and high end bracket the measured number.
By their numbers in this assay, from the lowest: compounds 4, 1 and 3 (each within the scatter of the next, the first and the last beyond it). At a limit, above all of these: compound 2.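

In this assay, within the data shown here, this pair is the first to isolate the extension, and it gives a 1.6-fold lower number from compound 1 to compound 4 (0.19 log units; within the scatter) for 2-(hydroxycarbamoyl)ethyl in place of hydroxycarbamoyl on a saturated chain carbon, five bonds along the chain from an oxygen on an aromatic ring. Among these compounds, the two chain lengths therefore cannot be told apart on this read-out, so this position accepts the longer chain with its terminal hydroxamic acid and the core of compound 1 unchanged, which the earlier compounds could not show because none of them formed such a pair with a shared core. Nothing available here bears on why the two chains read alike.

On these data alone, it remains open whether a still longer chain at this place would also read alike, or whether a carboxylic acid in place of the hydroxamic acid at the end of the ether chain would keep the inhibition of growth. The compounds shown also leave open what replacing the second hydroxamic acid on the core with a carboxylic acid or a primary amide would do.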